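Compound 2 to compound 4: chloro in place of methyl

The source may report more compounds than this note shows. Statements on the series, on what has been measured and on what is new or still open speak of the compounds shown alone.

- compound 1 (`Cc1cc(NC(=O)Nc2ccc(C(C)(C)C)cc2)c2ccccc2n1`) gives > 25000 nM, a limit
- compound 2 (`Cc1cc(NC(=O)Nc2ccc(C)c(Cl)c2)c2ccccc2n1`) gives > 25000 nM, a limit
- compound 3 (`Cc1cc(NC(=O)Nc2ccccc2OC(F)(F)F)c2ccccc2n1`) gives > 25000 nM, a limit

All three readings come from an ADME assay on HEK293 cells (Homo sapiens) for cytotoxicity, with a stated time of 72 h (on this read-out higher numbers stand for an effect only at larger amounts of compound and lower numbers for an effect already at smaller amounts), and none of them is a number. Among the measured compounds shown here, the series so far shows (the limit of > 25000 nM in this assay, at which 3 of the 3 values shown sit), and no measured compound goes against that.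

Compound 2 gives > 25000 nM, which is a limit, so its place on the scale is not fixed by a number. It shares this position with compound 1 and compound 3.

Compound 4 (`Cc1cc(NC(=O)Nc2ccc(Cl)c(Cl)c2)c2ccccc2n1`) has not yet been measured. It differs from compound 2 in one place: chloro in place of methyl on an aromatic carbon. This is chloro in place of methyl on an aromatic carbon, ortho to a chloro group and para to a large group.

The size of a single change in this series has not been measured, so the expectation rests only on the shared limit. No step beyond the scatter is expected in this assay, and the most likely outcome is another limit. The estimated change is a number no higher from compound 2 to compound 4 (the limit leaves the size open) in that reading. For compound 4 the estimate is 25000 nM, with an expected range from 10000 nM to 40000 nM around it.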

Compound 4, half-maximal effective concentration: > 25000 nM
Compound 4 ended at the assay's limit; the forecaster's own chance of this, stated with the estimate: 75%; the middle value lies on the limit itself.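

In this assay compound 4 gives > 25000 nM, a limit. Compound 2 gives > 25000 nM, also a limit. Among the compounds shown here, no step can therefore be read between compound 2 and compound 4. The compounds shown leave open the size of any single change and whether any change in the series would yield a value that is not a limit: the limit of > 25000 nM in this assay, at which 4 of the 4 values shown sit.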